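The source may hold more compounds than are shown below. What is called first, only, known or untested is meant among the compounds shown, and "the series" means these compounds.

Working notes on the series. Going by the values given here, compound 1, `COc1cccc(N2C(=O)COc3ccc(-c4cnc(Cl)c(NS(=O)(=O)c5ccc(F)cc5)c4)cc32)c1`, is the only member with a number in a functional assay on A549 cells (Homo sapiens) for antiproliferative activity, read by MTT assay, with a stated time of 72 h (on this read-out lower numbers stand for stronger inhibition and higher numbers for weaker inhibition), where compound 1 gives 32700 nM. Compound 2, `Cc1ccc(N2C(=O)COc3ccc(-c4cnc5ccccc5c4)cc32)cc1`, reaches only the limit of this assay, and compound 2 gives > 40000 nM. Compound 3, `O=C1COc2ccc(-c3cnc4ccccc4c3)cc2N1c1ccccc1`, likewise reaches only the limit of this assay, and compound 3 gives > 40000 nM. Among the compounds with values here, the one step between measured compounds that differ in a single place, a step that the two limits leave unreadable from compound 2 to compound 3, cannot be read because both ends sit at the limit of > 40000 nM in this assay, at which 2 of the 3 values shown sit.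

Compound 4, `O=C1COc2ccc(-c3cnc(Cl)c(NS(=O)(=O)c4ccc(F)cc4)c3)cc2N1c1ccc(F)cc1`, differs from compound 1 in one place: 4-fluorophenyl in place of 3-methoxyphenyl on an amide-type nitrogen in a ring. Within the data shown here, no measured step touches this part of the shared core; the only measured step concerns a different group on another core and yields no size. Nothing measured therefore points to a change in either direction, and the step from compound 1 to compound 4 is expected to stay within the scatter, a 1.1-fold lower number from compound 1 to compound 4 (0.04 log units; within the scatter). Compound 4 is thus expected to give 30000 nM in this assay, with a range from 10000 nM to 90000 nM, and with a fair chance that this assay returns only a limit for compound 4.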

Compound 4, half-maximal inhibitory concentration: 22300 nM
Compound 4: the middle estimate sits 1.3-fold (0.13 log units) above what was measured; measured number inside the range.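

In this assay, going by these compounds alone, the exchange on the amide-type nitrogen in a ring gives the first step at this position with a readable size: a 1.5-fold lower number from compound 1 to compound 4 (0.17 log units; within the scatter). On the shared core of compound 1, the read-out therefore does not separate 3-methoxyphenyl from 4-fluorophenyl, although the exchange removes the oxygen of the methoxy group and its hydrogen-bond acceptor and brings in a fluorine. The only earlier step, which concerns a methyl group on the aromatic ring at this same position, cannot be read, as both of its ends are limits and not numbers: the limit of > 40000 nM in this assay, at which 2 of the 4 values shown sit.

On these data alone, whether anything other than a substituted phenyl on this nitrogen, such as a plain methyl, a benzyl or a phenyl bearing an amine or a carboxylic acid, would move the number beyond the scatter stays open. Also open, as far as these compounds go, is whether 4-fluorophenyl on the core of compound 2 would bring that core off its limit, and whether the small size of this step holds on any core other than that of compound 1.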